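The source may report more compounds than this note shows. Statements on the series, on what has been measured and on what is new or still open speak of the compounds shown alone.

Going by the values given here, compound 1 `O=C(c1cscn1)N1CCC(C(=O)N2N=CC[C@H]2c2ccccc2)CC1` is one of three compounds measured in a physicochemical assay for lipophilicity, read by HPLC, measured as chromatographic lipophilicity, at pH 7.4 (a lower number here means a more polar compound, a higher number a more lipophilic compound), where compound 1 gives 3, the lowest of the three numbers. Compound 2 `O=C(C1CCOCC1)N1N=CCC1c1ccccc1` gives 3.1, which lies within the scatter of compound 1, so the two cannot be told apart. Compound 3 `CC1=NN(C(=O)C(C)(C)C)[C@H](c2ccccc2)C1` gives 6.4, far higher than compound 1 and beyond the scatter. Compound 4 `O=C(C1CCN(c2ccccc2)CC1)N1N=CC[C@H]1c1ccccc1` has not yet been measured. It differs from compound 1 in one place: phenyl in place of (1,3-thiazol-4-yl)carbonyl on an amine nitrogen in a ring. Among the compounds with values here, no step between two measured compounds shows this change, so the expectation rests on the change alone. A rise beyond the scatter is expected, so that the step of a number 1.80 log units higher from compound 1 to compound 4 (beyond the scatter) is estimated as a sizeable increase. Compound 4 is therefore expected to give about 4.8, in a range from 4 to 5.6.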

Compound 4, distribution coefficient: 6.3
For compound 4 the middle estimate is 1.50 log units below the measured one, outside the stated range (above it).
By their numbers in this assay, from the lowest: compounds 1 and 2 (each within the scatter of the next); then compounds 4 and 3 (each within the scatter of the next).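

In this assay, the group on this amine nitrogen in a ring proves far from neutral: phenyl in place of (1,3-thiazol-4-yl)carbonyl gives a number 3.30 log units higher from compound 1 to compound 4 (beyond the scatter). The group that leaves carries a carbonyl and a five-membered aromatic ring with 2 hetero atoms, while phenyl has no hetero atoms, so this one step changes several things at once. No measurement here explains its size. On these data alone, it remains open whether the carbonyl or the ring accounts for the step. A benzoyl group on this nitrogen would keep the carbonyl and change only the ring.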